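Chlorophenoxy variation on the shared core, antiproliferative read-out

This account rests on a few compounds, and the source may have more. Where it says the series, first, only, none or still open, it means among the compounds named here.

Measured compounds:
compound 1, `NC1=NC2(CCSCC2)N(OCCCOc2cccc(Cl)c2)C(N)=N1`: 1 nM
compound 2, `NC1=NC2(CCOCC2)N(OCCCOc2ccc(Cl)cc2)C(N)=N1`: 690 nM
compound 3, `NC1=NC2(CCSCC2)N(OCCCOc2cc(Cl)c(Cl)cc2Cl)C(N)=N1`: 1 nM

In a functional assay on HCT-116 cells (Homo sapiens) for antiproliferative activity, read by MTT assay, with a stated time of 72 h (on this read-out lower numbers stand for stronger inhibition and higher numbers for weaker inhibition), compound 1 gives 1 nM and compound 3 gives 1 nM, while compound 2 gives 690 nM. Compound 2 thus stands highest of the three numbers, and its gap to compound 1 and to compound 3 lies beyond the scatter in either case. Compound 2 differs from compound 1 in more than one place, so this gap cannot be tied to a single change; only what the two values show can be said.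

Compound 4, `NC1=NC2(CCOCC2)N(OCCCOc2ccccc2)C(N)=N1`, is compound 2 with hydrogen in place of chloro on an aromatic carbon. Among the measured compounds shown here, no measured step removes a chlorine from the aromatic ring. For the measured compounds named here, the single step that bears on the chlorine pattern of that ring runs the other way: no change at the digits printed from compound 1 to compound 3 (within the scatter), where 2,4,5-trichlorophenyl replaces 3-chlorophenyl. Chlorine substitution on this ring therefore left the read-out unmoved in the one case available, and the same is expected here. For compound 4 a step of a 1.3-fold higher number from compound 2 to compound 4 (0.12 log units; within the scatter) is expected, that is, no change beyond the scatter. Compound 4 is estimated at 900 nM, with a range of 250 nM to 3500 nM.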

Compound 4, half-maximal inhibitory concentration: 6010 nM
Compound 4: the middle estimate sits 6.7-fold (0.82 log units) below what was measured, and the stated range ends below it.
By their numbers in this assay, from the lowest: compounds 1 and 3 (each within the scatter of the next); then compound 2; then compound 4.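

In this assay, the change from 4-chlorophenyl to phenyl gives an 8.7-fold higher number from compound 2 to compound 4 (0.94 log units; beyond the scatter), so on the core of compound 2 a single chloro on the aromatic carbon para to a large group is tied to a shift beyond the scatter, the first such single-place shift in the series. This differs from no change at the digits printed from compound 1 to compound 3 (within the scatter) on the core of compound 1, where a change in the chlorine pattern left the printed read-out in place; chlorine on this ring therefore does not behave alike in the two steps, which differ in both core and type of change, and compounds 1 and 3 go against any general claim that chlorine pattern sets the read-out. No measurement at hand gives a reason for the step from compound 2 to compound 4.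

As far as these compounds go, whether fluoro, bromo, methoxy or an amine at the same aromatic carbon would hold the read-out near that of compound 2 or fall toward that of compound 4 remains open. Also open, from the compounds shown here alone, is whether replacing chloro with hydrogen on the core of compound 1 would give a step of similar size.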